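Swapping the Outer Ring of Compound 1

The source may hold more compounds than are shown below. What is called first, only, known or untested is meant among the compounds shown, and "the series" means these compounds.

Compound 1 `COC(=O)/C=C/c1cccc(N(Cc2ccc(-c3ccc(SC)cc3)cc2)C(=O)C(C)C)c1` was tested in an assay on isolated protein with Bile acid receptor (Homo sapiens) as the target (on this read-out higher numbers stand for an effect only at larger amounts of compound and lower numbers for an effect already at smaller amounts), and gives 51 nM, the lowest of the two numbers measured here. Compound 2 `COC/C=C/c1cccc(N(Cc2ccc(/C=C/C(=O)OC(C)(C)C)cc2)C(=O)C2CCCCC2)c1` gives 243 nM, a higher number beyond the scatter. Compound 3 `CC(C)(C)OC(=O)/C=C/c1ccc(CN(C(=O)C2CCCCC2)c2cccc(/C=C/C(=O)OC(C)(C)C)c2)cc1` reaches only > 1000 nM, which is a limit of the assay rather than a number. Within the data shown here, the single measured step, an at least 4.1-fold higher number from compound 2 to compound 3 (0.61 log units; beyond the scatter), concerns a different part of the molecule. Compound 4 `COC(=O)/C=C/c1cccc(N(Cc2ccc(-c3ccc(F)c(Cl)c3)cc2)C(=O)C(C)C)c1` differs from compound 1 by 3-chloro-4-fluorophenyl in place of 4-(methylsulfanyl)phenyl on an aromatic carbon. Among the measured compounds shown here, no measured step touches this ring, so the expectation rests on the two groups matching in what is counted for them. The step of a 1.4-fold higher number from compound 1 to compound 4 (0.14 log units; within the scatter) is expected to stay within the scatter. Compound 4 is therefore estimated at 70 nM, between 25 nM and 250 nM.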

Compound 4, half-maximal effective concentration: 129 nM
Estimate against measurement, compound 4: 1.8-fold (0.27 log units) below; measured number inside the range.
By their numbers in this assay, from the lowest: compound 1; then compounds 4 and 2 (each within the scatter of the next). At a limit, above all of these: compound 3.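

In this assay, among these compounds, the step of a 2.5-fold higher number from compound 1 to compound 4 (0.40 log units; beyond the scatter) is the first measured change at this position, and it shows that the outer ring can be exchanged with only a modest shift, though one that is real. The two rings match in heavy-atom count and ring type, so those counts alone do not fix the number. Nothing measured here explains the shift.

Going by these compounds, it remains open whether the chlorine or the fluorine matters more when each stands alone on the ring. How an amine or a carboxylic acid would behave on this ring is also unknown.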